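Compound 3 gains a larger group on its methyl carbon

The source may hold more compounds than are shown below. What is called first, only, known or untested is meant among the compounds shown, and "the series" means these compounds.

In a functional assay on HCT-116 cells (Homo sapiens) for antiproliferative activity, read by MTT assay, with a stated time of 72 h (a lower number here means a stronger inhibitor, a higher number a weaker inhibitor), compound 1 (`CCNC(=O)CCc1cccc2c1B(O)OC2`) gives > 100000 nM as a limit of the assay, not a number. Compound 2 (`O=C(CCc1cccc2c1B(O)OC2)NCc1ccccc1`) likewise gives > 100000 nM as a limit. Compound 3 (`Cc1ccc(NC(=O)CCc2cccc3c2B(O)OC3)cc1`) gives 4500 nM and is the only one of the three with a true number.

Placing 4-methylphenyl on the amide-type nitrogen gave an at least 22-fold lower number from compound 1 to compound 3 (1.34 log units; beyond the scatter) in place of ethyl, and an at least 22-fold lower number from compound 2 to compound 3 (1.34 log units; beyond the scatter) in place of benzyl. These large steps are the only readable ones so far.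

Compound 4 (`CC(C)(C)OC(=O)NCc1ccc(NC(=O)CCc2cccc3c2B(O)OC3)cc1`) differs from compound 3 by (tert-butoxycarbonyl)amino in place of hydrogen on a saturated chain carbon bound to an aromatic carbon with (tert-butoxycarbonyl)amino in place of hydrogen on a saturated chain carbon bound to an aromatic carbon. Methyl thus becomes ((tert-butoxycarbonyl)amino)methyl. Neither measured step touched this carbon, so neither gives a size for the new change. Compound 4 does keep an aromatic ring on the amide-type nitrogen, so a true number is expected in this assay rather than a limit. The expected change is a 1.3-fold higher number from compound 3 to compound 4 (0.12 log units; within the scatter) by this estimate, which means no step beyond the scatter, with any real shift more likely toward a higher number. For compound 4 the estimated value is 6000 nM with 1200 nM to 40000 nM as the expected range.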

Compound 4, half-maximal inhibitory concentration: 2300 nM
Compound 4: middle estimate off by 2.6-fold (0.42 log units), on the high side, and the stated range covers the measured number.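

In this assay, (tert-butoxycarbonyl)amino in place of hydrogen on a saturated chain carbon bound to an aromatic carbon gives a 2.0-fold lower number from compound 3 to compound 4 (0.29 log units; within the scatter), so a group of 8 heavy atoms enters here with no step beyond the scatter. The earlier steps shown here changed only the group on the amide-type nitrogen, whereas this one leaves the 4-methylphenyl ring in place and alters its methyl carbon, and it shows that this carbon can carry a much bulkier substituent while the compound still gives a true number rather than a limit. Compound 1 and compound 2 each remain at a limit of the assay, not a number, so the step between them cannot be read: the limit of > 100000 nM in this assay, at which 2 of the 4 values shown sit.

With only one new group on this carbon, the compounds shown do not separate the part played by the tert-butoxycarbonyl portion from that of the nitrogen it protects. A free amine or a carboxylic acid at this carbon would test whether the tolerance seen here extends to very different groups, and a longer chain between the ring and the group would test how far out it reaches.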